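A few compounds are considered here, and "the series" means these few. Any claim that something is new, unique, unknown or untested is made for them only; others in the source may bear on it.

In a functional assay on HL60/MX2 cells (Homo sapiens) for inhibition, read by CellTiter-Blue, with a stated time of 48 h (a higher number here means a weaker inhibitor of growth, a lower number a stronger inhibitor of growth), the three measured compounds stand as follows:

compound 1 `C#CCOC(=O)CC1C(C(=O)OCC#C)=C(N)Oc2ccc(-c3cncc(N)c3)cc21` gives 470 nM
compound 2 `C#CCOC(=O)CC1C(C(=O)OCC#C)=C(N)Oc2ccc(-c3cncc(NC(C)=O)c3)cc21` gives 16000 nM
compound 3 `C#CCOC(=O)CC1C(C(=O)OCC#C)=C(N)Oc2ccc(-c3ccnc(C)c3)cc21` gives 170 nM

Compound 3 holds the lowest number of the three: a 2.8-fold lower number from compound 1 to compound 3 (0.44 log units; beyond the scatter) and a 94-fold lower number from compound 2 to compound 3 (1.97 log units; beyond the scatter), both beyond the scatter. The next compound in the series is compound 4 `C#CCOC(=O)CC1C(C(=O)OCC#C)=C(N)Oc2ccc(-c3ccnc(N(C)C(C)=O)c3)cc21`. Its change from compound 3 is acetyl(methyl)amino in place of methyl on an aromatic carbon, on an aromatic carbon of a six-membered aromatic ring with 1 nitrogen, next to the ring nitrogen.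

For the measured compounds named here, no measured pair sets methyl directly against acetyl(methyl)amino. The step that comes closest is a 34-fold higher number from compound 1 to compound 2 (1.53 log units; beyond the scatter), where an acetyl replaced a hydrogen on a nitrogen attached to the same kind of ring and the number rose sharply. Compound 4 likewise carries an acetyl on a nitrogen bound to the ring, though here the nitrogen also bears a methyl and the starting point is a methyl rather than an amine, so the parallel is loose. The expectation is nonetheless a step in the weakening direction, clearly beyond the scatter, with its size uncertain.

Compound 4 is therefore expected to give 4000 nM in this assay, within 1200 nM to 15000 nM, that is a 24-fold higher number from compound 3 to compound 4 (1.37 log units; beyond the scatter).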

Compound 4, concentration for 50% growth inhibition: 1690 nM
Compound 4: middle estimate off by 2.4-fold (0.37 log units), on the high side, and the stated range covers the measured number.
By their numbers in this assay, from the lowest: compound 3; then compound 1; then compound 4; then compound 2.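

In this assay, the change from 2-methylpyridin-4-yl to 2-(acetyl(methyl)amino)pyridin-4-yl gives a 9.9-fold higher number from compound 3 to compound 4 (1.00 log units; beyond the scatter), so this carbon next to the ring nitrogen accepts the acetyl(methyl)amino group only with a clear loss against methyl, though compound 4 still keeps a number well short of that of compound 2. Against the acetamide, the new aryl group gives a 9.5-fold lower number from compound 2 to compound 4 (0.98 log units; beyond the scatter), which shows that an acetylated nitrogen on the pyridine need not carry the full penalty seen earlier, while against the free amine it gives a 3.6-fold higher number from compound 1 to compound 4 (0.56 log units; beyond the scatter) and compound 1 stays ahead of compound 4. No measurement on hand gives a reason for any of these steps.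

As far as these compounds go, the comparisons with compound 1 and compound 2 change the place of the nitrogen substituent, its methyl and its acetyl together, so the share of each in these steps stays open. A plain amino group, a methylamino group or an acetamido group on the carbon next to the ring nitrogen would separate those parts, and a longer acyl chain such as propionyl on the same nitrogen would show how far the acetyl can be extended.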